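A few compounds are considered here, and "the series" means these few. Any claim that something is new, unique, unknown or untested is made for them only; others in the source may bear on it.

Compound 1 `CCCOC(=O)Nc1ccc(S(=O)(=O)N2C[C@H](c3ccccc3)NC2=O)cc1CC` gives 60 nM in a functional assay on HCT-116 cells (Homo sapiens) for cytotoxicity, read by MTT assay; a lower number here means a stronger inhibitor, a higher number a weaker inhibitor.
Compound 2 `CCc1cc(S(=O)(=O)N2C[C@H](c3ccccc3)NC2=O)ccc1NC(=O)c1ccc([N+](=O)[O-])cc1` gives 500 nM in this assay.
Compound 3 `CCc1cc(S(=O)(=O)N2C[C@H](c3ccccc3)NC2=O)ccc1NC(=O)OC(C)C` gives 60 nM in this assay.

Compound 3 shares its number with compound 1 at the digits printed, and the two sit well apart from compound 2: an 8.3-fold lower number from compound 2 to compound 3 (0.92 log units; beyond the scatter), a step beyond the scatter. Within the data shown here, the one change already measured at the oxygen next to a carbonyl group, no change at the digits printed from compound 1 to compound 3 (within the scatter), left the number unchanged within the scatter, while the larger changes on the carbonyl carbon itself, an 8.3-fold higher number from compound 1 to compound 2 (0.92 log units; beyond the scatter) and an 8.3-fold lower number from compound 2 to compound 3 (0.92 log units; beyond the scatter), moved it modestly.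

Compound 4 `CCc1cc(S(=O)(=O)N2C[C@H](c3ccccc3)NC2=O)ccc1NC(=O)OCC(C)C` differs from compound 3 in one place: isobutyl in place of isopropyl on an oxygen next to a carbonyl group. This is the same kind of small change on the same oxygen as the step from compound 1 to compound 3, which lay within the scatter, so no step beyond the scatter is expected in this assay in either direction. Compound 4 is therefore estimated at 60 nM, within 30 nM to 150 nM, which means an expected step of no change at the digits printed from compound 3 to compound 4 (within the scatter).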

Compound 4, half-maximal inhibitory concentration: 60 nM
Estimate against measurement, compound 4: no gap at the digits printed, within the range that was stated.
By their numbers in this assay, from the lowest: compounds 1, 3 and 4 (each within the scatter of the next); then compound 2.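

On the oxygen next to a carbonyl group, a third small chain now reads the same in this assay: isobutyl in place of isopropyl gives (no change at the digits printed from compound 3 to compound 4 (within the scatter)), and isobutyl against the unbranched propyl gives (no change at the digits printed from compound 1 to compound 4 (within the scatter)). The gap to the 4-nitrophenyl compound also holds for this new chain (an 8.3-fold lower number from compound 2 to compound 4 (0.92 log units; beyond the scatter)), so chains of 3 and 4 carbons, straight or branched, all sit level here. Nothing measured here explains why these chains read alike.

The compounds shown leave open whether a much longer chain such as octyl, or a chain carrying an amine or a carboxylic acid, would stay level on this oxygen. They also leave open how a plain phenyl on the carbonyl carbon would compare with 4-nitrophenyl.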